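Methoxy for chloro on the sulfonamide of compound 1

This account rests on a few compounds, and the source may have more. Where it says the series, first, only, none or still open, it means among the compounds named here.

Compound 1, `O=S(=O)(Nc1ccc(-c2nc3ccccc3o2)cc1)c1cccc(Cl)c1`, is one of three sulfonamides on a shared core examined in an assay on isolated protein for inhibition of malate dehydrogenase, mitochondrial (Sus scrofa), with stated times of 45 min and 30 min; a lower number here means a stronger inhibitor, a higher number a weaker inhibitor. In this assay compound 1 gives > 63000 nM, which is a limit of the assay and not a number. Compound 2, `COc1ccc(Cl)cc1S(=O)(=O)Nc1ccc2oc(-c3ccccc3)nc2c1`, gives in this assay > 63000 nM, again a limit. Compound 3, `O=S(=O)(Nc1ccc2oc(-c3ccccc3)nc2c1)c1ccc(O)cc1`, gives in this assay > 63000 nM, also a limit. Going by the values given here, the single measured step between compounds that differ in one place, a step that the two limits leave unreadable from compound 2 to compound 3, is therefore unreadable in size and direction. Everything measured so far sits in one place: the limit of > 63000 nM in this assay, at which 3 of the 3 values shown sit.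

Compound 4, `COc1cccc(S(=O)(=O)Nc2ccc(-c3nc4ccccc4o3)cc2)c1`, differs from compound 1 in one place: methoxy in place of chloro on an aromatic carbon. Among the compounds with values here, no measured step touches this change, and the only step at hand is unreadable, so nothing points in either direction. With every value at the limit, the step that the limit leaves unreadable from compound 1 to compound 4 is expected to show no change beyond the scatter, and a limit rather than a number is the expected outcome. Compound 4 is estimated at 100000 nM, with a range from 30000 nM to 400000 nM.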

Compound 4, half-maximal inhibitory concentration: > 63000 nM
Compound 4: a limit, no number; the forecaster's own chance of this, stated with the estimate: 85%; the middle value lies beyond the limit too.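

The step between compound 1 and compound 4 cannot be read, and no new step follows from this result, with both compounds standing at a limit and not a number: the limit of > 63000 nM in this assay, at which 4 of the 4 values shown sit.

The compounds shown leave open whether any sulfonamide on the shared core gives a readable number in this assay, and so which groups affect inhibition.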